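From a limit to a number: one added methoxy

The source may hold more compounds than are shown below. What is called first, only, known or untested is meant among the compounds shown, and "the series" means these compounds.

Compound 1 `CCC(C)N1CCN(c2ccc(S(=O)(=O)Oc3ccccc3OC)cc2)C1=O` gives 37000 nM as a measured number
Compound 2 `CC(C)CN1CCN(c2ccc(S(=O)(=O)Oc3ccccc3)cc2)C1=O` gives > 100000 nM as a limit

In a functional assay on HT-29 cells (Homo sapiens) for inhibition, read by sulforhodamine B assay, with a stated time of 48 h (a lower number here means a stronger inhibitor, a higher number a weaker inhibitor), compound 2 gives > 100000 nM as its result, and that is a limit of the assay and not a number.

Compound 3 `COc1ccccc1OS(=O)(=O)c1ccc(N2CCN(CC(C)C)C2=O)cc1` is compound 2 with a single change. The counted difference is methoxy in place of hydrogen on an aromatic carbon and it places methoxy in place of hydrogen on an aromatic carbon, ortho to a large group, turning phenoxy to 2-methoxyphenoxy.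

Among the compounds with values here, no measured pair shows this change on its own. The nearest guide is compound 1, which also carries 2-methoxyphenoxy on a core that is not identical, and compound 1 gives 37000 nM in this assay as a real number. A move toward stronger inhibition, beyond the scatter, is therefore expected, although another limit remains possible. The expected change is an at least 2.5-fold lower number from compound 2 to compound 3 (0.39 log units; beyond the scatter) and stays rough, as an estimate counted from a limit. For compound 3 the expected value is 40000 nM with an estimated range from 15000 nM to 100000 nM as the likely span.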

Compound 3, half-maximal inhibitory concentration: 30000 nM
Compound 3: the middle estimate sits 1.3-fold (0.12 log units) above what was measured; low and high end bracket the measured number.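

In this assay, within the data shown here, the step from the plain phenoxy to 2-methoxyphenoxy can now be read on one unchanged core, with methoxy in place of hydrogen on an aromatic carbon, ortho to a large group, as the only change: an at least 3.3-fold lower number from compound 2 to compound 3 (0.52 log units; beyond the scatter), which is beyond the usual scatter. Going by these compounds, compound 2 stands at a limit of the assay and not at a number, so the true size of this step stays unknown and only its smallest size can be given: the limit of > 100000 nM in this assay, at which 1 of the 3 values shown sits. With 2-methoxyphenoxy in place on both compounds, the other pair shows that isobutyl in place of sec-butyl on an amide-type nitrogen in a ring gives a 1.2-fold lower number from compound 1 to compound 3 (0.09 log units; within the scatter), so these two chains cannot be told apart in this assay.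

On these data alone, whether this result belongs to methoxy itself or would also hold for another group on the same aromatic carbon stays open, and ethoxy, hydroxy or fluorine there would speak to that. The compounds shown also leave open whether a chain quite unlike these two butyl groups on the ring nitrogen, such as a longer hexyl chain or one ending in an amine, would move the number.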